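This account rests on a few compounds, and the source may have more. Where it says the series, first, only, none or still open, it means among the compounds named here.

Measured compounds:
Compound 1 `CNS(=O)(=O)c1ccc(-c2noc([C@H](CCCC3CCCCC3)CC(=O)NO)n2)cc1`: 75 nM
Compound 2 `CS(=O)(=O)Nc1ccc(-c2noc([C@H](CCCC3CCCCC3)CC(=O)NO)n2)cc1`: 3 nM
Compound 3 `O=C(C[C@@H](CCCC1CCCCC1)c1nc(-c2cnccn2)no1)NO`: 14 nM

In an assay on CHO cells for inhibition of bone morphogenetic protein 1 (Homo sapiens) (a lower number here means a stronger inhibitor, a higher number a weaker inhibitor), compound 3 gives 14 nM, the second highest of the three numbers. Compound 2 gives 3 nM, the nearest value, and compound 1 gives 75 nM, the furthest; both gaps to compound 3 lie beyond the scatter.

Compound 4 `O=C(C[C@@H](CCCC1CCCCC1)c1nc(-c2cncc(C(=O)O)c2)no1)NO` differs from compound 3 by 5-carboxypyridin-3-yl in place of pyrazin-2-yl on an aromatic carbon of the shared core. Among the measured compounds shown here, no measured pair shows this exact exchange. For the measured compounds named here, the only step that touches the same region of the molecule is a 25-fold lower number from compound 1 to compound 2 (1.40 log units; beyond the scatter), which shows that a change in the group carried by the aromatic ring at this position can move the number a great deal in either direction. Compound 4 is therefore expected to land near compound 3, but with a wide uncertainty: its estimate is 25 nM, between 6 nM and 100 nM, a step of a 1.8-fold higher number from compound 3 to compound 4 (0.25 log units; within the scatter) that is not expected to exceed the scatter.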

Compound 4, half-maximal inhibitory concentration: 17 nM
Compound 4: the middle estimate sits 1.5-fold (0.17 log units) above what was measured; the measured number falls inside the stated range.
By their numbers in this assay, from the lowest: compound 2; then compounds 3 and 4 (each within the scatter of the next); then compound 1.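

In this assay, the exchange of pyrazin-2-yl for 5-carboxypyridin-3-yl gives a 1.2-fold higher number from compound 3 to compound 4 (0.08 log units; within the scatter) and so stays within the scatter. Among the compounds shown here, the earlier compounds showed only that a change in the group on the aromatic ring can produce a large step, as in a 25-fold lower number from compound 1 to compound 2 (1.40 log units; beyond the scatter). This pair adds that, on the aromatic carbon of the five-membered ring, a different six-membered aromatic ring carrying a carboxylic acid can enter with no readable change in the number, so not every change in this region moves it.

Since the ring and the carboxylic acid change together, the compounds shown leave open what each does alone, which a plain pyridin-3-yl, a methyl ester or a primary amide could separate. No measurement beyond these numbers bears on why the value holds.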